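The compounds below may be only part of what the source reports. "The series", "measured", "known", "first", "only" and "open" are said of these compounds alone.

Compound 1 `N#CCN(Cc1ccccc1)Cc1ccc(Cl)cc1` gives 0% in an assay on HEK293 cells for binding affinity to Substance-K receptor (Rattus norvegicus), read by FRET, tested at 10 uM; a lower number here means less inhibition, a higher number more inhibition at the concentration tested (going by the name of the read-out).
Compound 2 `CCOC(=O)CCCCN(Cc1ccccc1)Cc1ccc2ccccc2c1` gives 0% in this assay.

Compound 2 stands level with compound 1 in this assay, the two values being the same at the digits shown and within the scatter. Compound 3 `O=C(CN(Cc1ccccc1)Cc1ccc2ccccc2c1)N1CCCCC1` differs from compound 2 in one place: (piperidin-1-yl)carbonyl in place of 3-(ethoxycarbonyl)propyl on a saturated chain carbon bound to an amine nitrogen. Going by the values given here, no step between two measured compounds covers this change, so nothing shows how it acts. Because compound 2 gives 0% in this assay, no step beyond the scatter is expected. The expected step from compound 2 to compound 3 is a number 5 percentage points higher from compound 2 to compound 3 (within the scatter). Compound 3 is therefore estimated at 5%, with a range from 0% to 30%.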

Compound 3, a percentage reported as inhibition, at one concentration (the size of the read-out at that concentration, not a potency): 0%
Compound 3: the middle estimate sits 5 percentage points above what was measured, within the range that was stated.
By their numbers in this assay, from the lowest: compounds 1, 2 and 3 (each within the scatter of the next).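

In this assay, putting (piperidin-1-yl)carbonyl in place of 3-(ethoxycarbonyl)propyl on a saturated chain carbon bound to an amine nitrogen gives no change at the digits printed from compound 2 to compound 3 (within the scatter). This position has now carried two different groups, one with a ring and one without, and neither shows inhibition that can be told from that of the other. Nothing measured here offers an explanation for this result. On these data alone, whether a carboxylic acid or a primary amine at this position would produce measurable inhibition remains open.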